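The source may report more compounds than this note shows. Statements on the series, on what has been measured and on what is new or still open speak of the compounds shown alone.

Compound 1 `COCCNS(=O)(=O)c1ccc(-c2ccnc3[nH]ccc23)cc1` gives > 30000 nM in an assay on isolated protein for inhibition of serine/threonine-protein kinase Nek1 (Homo sapiens), read by TR-FRET, with a stated time of 30 min (on this read-out lower numbers stand for stronger inhibition and higher numbers for weaker inhibition), which is a limit of the assay and not a number. Compound 2 `CC(C)(O)CNS(=O)(=O)c1ccc(-c2ccnc3[nH]ccc23)cc1` gives 5800 nM in this assay.

Compound 2 thus holds the only number shown in this assay; the remaining value sits at a limit, as the evidence notes (the limit of > 30000 nM in this assay, at which 1 of the 2 values shown sits). Within the data shown here, the one step between the two, an at least 5.1-fold lower number from compound 1 to compound 2 (0.71 log units; beyond the scatter), lies beyond the scatter and shows that the group on the sulfonamide nitrogen matters for this read-out.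

Compound 3 `CN1CCN(S(=O)(=O)c2ccc(-c3ccnc4[nH]ccc34)cc2)CC1` has not yet been measured. It differs from compound 2 by 4-methylpiperazin-1-yl in place of (2-hydroxy-2-methylpropyl)amino on a sulfonyl sulfur. The step from compound 1 to compound 2 bears on this change only loosely: it concerned the chain on the nitrogen, whereas here the whole amino substituent gives way to a ring and the hydrogen-bond donors counted above disappear. Given that the step from compound 1 to compound 2 ran toward the limit when the hydroxyl was absent, compound 3 is expected to move back toward weaker inhibition, with the step of a 2.6-fold higher number from compound 2 to compound 3 (0.41 log units; beyond the scatter) estimated to lie beyond the scatter. Compound 3 is therefore estimated at 15000 nM, between 4000 nM and 60000 nM, with a real chance that this assay again reports only a limit.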

Compound 3, half-maximal inhibitory concentration: > 10000 nM
Compound 3 ended at the assay's limit (the forecaster's own chance of this, stated with the estimate: 40%); the middle value lies beyond the limit too.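

The value of compound 3 is a limit of the assay and not a number: the limit of > 10000 nM in this assay, at which 1 of the 3 values shown sits. Replacing (2-hydroxy-2-methylpropyl)amino with 4-methylpiperazin-1-yl on the sulfonyl sulfur gives an at least 1.7-fold higher number from compound 2 to compound 3 (0.23 log units; that floor lies within the scatter), so a loss of inhibition is not established, although a larger one remains possible. Among these compounds, what this adds is a first look at a ring on the sulfonyl sulfur, with 0 hydrogen-bond donors in the entering group, and it yields no number, while the step between compound 1 and compound 3 cannot be read, as both values are limits.

The compounds shown leave open how far the true value of compound 3 lies from that of compound 2, and so whether 4-methylpiperazin-1-yl costs anything at all in this read-out. They also leave open whether a morpholine ring on the sulfonyl sulfur, or a longer chain ending in a hydroxyl on the sulfonamide nitrogen, would match or improve on compound 2 at 5800 nM.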